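The source may hold more compounds than are shown below. What is called first, only, known or untested is meant among the compounds shown, and "the series" means these compounds.

Measured so far in an ADME assay on HEK293 cells (Homo sapiens) for inhibition, read by CellTiter-Glo, with a stated time of 96 h, tested at 100 uM; on this read-out lower numbers stand for less inhibition and higher numbers for more inhibition at the one concentration tested (going by the name of the read-out):

Compound 1 `CC(C)(CO)[C@H](O)C(=O)N/C=C/C(=O)OCc1ccccc1` gives -6%.
Compound 2 `COC(=O)/C=C/NC(=O)[C@@H](O)C(C)(C)CO` gives -2%.
Compound 3 `COC(=O)/C=C\NC(=O)[C@@H](O)C(C)(C)CO` gives -12%.

All three numbers sit close together. Compound 2 and compound 3 share the same atoms and bonds, (the two compounds have the same atoms and bonds and differ only in configuration as drawn: 1 of 2 stereo elements differ; a double bond is drawn E in compound 2 and Z in compound 3); that fact the fact that compounds 2 and 3 differ only in the configuration as drawn accompanies a step of a number 10 percentage points lower from compound 2 to compound 3 (within the scatter). From compound 2 to compound 1 the change is phenyl in place of hydrogen on a saturated chain carbon bound to an oxygen next to a carbonyl group, and the step it made was a number 4 percentage points lower from compound 2 to compound 1 (within the scatter).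

Compound 4 `CC(C)(CO)[C@H](O)C(=O)N/C=C\C(=O)OCc1ccccc1` has not yet been measured in this assay. It differs from compound 3 by phenyl in place of hydrogen on a saturated chain carbon bound to an oxygen next to a carbonyl group, the same change that turned compound 2 into compound 1. Because a number 4 percentage points lower from compound 2 to compound 1 (within the scatter) stayed within the scatter, an equally small step is expected here, a number 1 percentage points lower from compound 3 to compound 4 (within the scatter). Compound 4 is therefore estimated to give -13% in this assay, with a likely range from -26% to 2%.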

Compound 4, a percentage reported as inhibition, at one concentration (the size of the read-out at that concentration, not a potency): -7%
Beside the measured number, compound 4's estimate is 6 percentage points below it, within the range that was stated.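

Putting phenyl in place of hydrogen on a saturated chain carbon bound to an oxygen next to a carbonyl group gives in this assay a step of a number 5 percentage points higher from compound 3 to compound 4 (within the scatter), and changing the double bond with this group in place gives a number 1 percentage points lower from compound 1 to compound 4 (within the scatter). The change behaves alike on both cores, as far as these numbers can tell: the same change on two cores in this assay, a number 4 percentage points lower (within the scatter) from compound 2 to compound 1 and a number 5 percentage points higher (within the scatter) from compound 3 to compound 4, 9 percentage points apart, within the scatter of two such steps This shows that the step stayed small on both cores, but it does not show that the change has any real effect, or that a larger step would carry over in the same way.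

Still open, from the compounds shown here alone, is whether an amine or a carboxylic acid at this place would give a step beyond the scatter.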